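Methyl to phenyl on the ring nitrogen of compound 3

The compounds below may be only part of what the source reports. "The series", "measured", "known", "first", "only" and "open" are said of these compounds alone.

Working notes on a small set measured in a functional assay on the whole organism (plasma, strain albino) for inhibition, with Rattus norvegicus as the target, with stated times of 1 h and 4 h, at a dose of 50 mg/kg by the oral route; a higher number here means a stronger effect of the compound at the dose given, a lower number a weaker effect. Compound 1 `COc1ccc(/C=C/C(=O)c2ccc(NC(=O)c3cc(Cl)ccc3OC)cc2)cc1` gives 79.2% there. Compound 2 `COc1ccc(Cl)cc1C(=O)Nc1ccc(C2=NN(C)C(c3ccccc3[N+](=O)[O-])C2)cc1` gives 91.3% in this assay. Compound 3 `COc1ccc(Cl)cc1C(=O)Nc1ccc(C2=NN(C)C(c3ccc([N+](=O)[O-])cc3)C2)cc1` gives 83.2% in this assay. On the numbers shown, compound 3 lies with compound 1 and compound 2 inside the usual scatter of the readings, so no order among the three can be read off. Going by the values given here, the one measured single-point step, a number 8.1 percentage points lower from compound 2 to compound 3 (within the scatter), concerns the group on the saturated ring carbon and not the ring nitrogen.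

Compound 4 `COc1ccc(Cl)cc1C(=O)Nc1ccc(C2=NN(c3ccccc3)C(c3ccc([N+](=O)[O-])cc3)C2)cc1` is not yet measured. The change from compound 3 to compound 4 is phenyl in place of methyl on an amine nitrogen in a ring. Among the compounds with values here, no measured pair in the set alters the substituent on the amine nitrogen in the ring, so there is no direct precedent for this change, and the only step at hand stayed within the scatter. The expectation for compound 4 in this assay is therefore a step of a number 3.2 percentage points lower from compound 3 to compound 4 (within the scatter) from compound 3, that is, none beyond the scatter. Compound 4 is estimated at 80% in this assay, with a range of 65% to 92%.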

Compound 4, a percentage reported as inhibition, in the whole organism at one dose (the size of the read-out at that dose, not a potency): 85.3%
The estimate for compound 4 lay 5.3 percentage points below the measured number; low and high end bracket the measured number.
By their numbers in this assay, from the lowest: compounds 1, 3, 4 and 2 (each within the scatter of the next, the first and the last beyond it).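

The ring nitrogen is the new position here: in this assay the change to phenyl from methyl gives a number 2.1 percentage points higher from compound 3 to compound 4 (within the scatter) with the 4-nitrophenyl group in place. Going by these compounds alone, this is the first reading at this position, and it shows that a six-membered aromatic ring of carbon only can stand on this amine nitrogen without a shift beyond the scatter, so the read-out at this single dose does not separate methyl from phenyl here. No measurement shown bears on why the two compounds read alike.

As far as these compounds go, whether methyl and phenyl also read alike with the 2-nitrophenyl group of compound 2 on the saturated ring carbon stays open, and a one-dose percentage says nothing about potency at this position. Also open, from the compounds shown here alone, is how this nitrogen responds to groups of another kind, such as an acetyl group, a longer alkyl chain, or a chain ending in a carboxylic acid or an amine.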